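This account rests on a few compounds, and the source may have more. Where it says the series, first, only, none or still open, it means among the compounds named here.

Measured compounds in a functional assay on NCI-H23 cells (Homo sapiens) for inhibition, read by sulforhodamine B assay, with a stated time of 48 h, tested at 10 uM; on this read-out lower numbers stand for less inhibition and higher numbers for more inhibition at the one concentration tested (going by the name of the read-out):
compound 1 `Brc1cn2ccnc2c(-c2ccc3ncn(C4CCCCC4)c3c2)n1` gives 10.2%
compound 2 `COc1ccc(-c2cn3ccnc3c(-c3ccc4ncn(C5CCCCC5)c4c3)n2)cc1` gives 62.2%
compound 3 `O=Cc1ccc(-c2cn3ccnc3c(-c3ccc4ncn(C5CCCCC5)c4c3)n2)cc1` gives 54.5%

Compound 3 stands second highest of the three numbers in this assay; its nearest neighbour is compound 2, with a number 7.7 percentage points lower from compound 2 to compound 3 (within the scatter), and the furthest is compound 1, with a number 44.3 percentage points higher from compound 1 to compound 3 (beyond the scatter).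

Compound 4 `c1cn2cc(-c3ccsc3)nc(-c3ccc4ncn(C5CCCCC5)c4c3)c2n1` is not yet measured. It differs from compound 3 in one place: thiophen-3-yl in place of 4-formylphenyl on an aromatic carbon. Both groups are aromatic rings carried on the same aromatic carbon of the shared core.

Among the compounds with values here, two measured steps bear on the change. Going from bromo to an aryl group at this carbon gives a number 52 percentage points higher from compound 1 to compound 2 (beyond the scatter) and a number 44.3 percentage points higher from compound 1 to compound 3 (beyond the scatter); the two aryl groups themselves sit close together, a number 7.7 percentage points lower from compound 2 to compound 3 (within the scatter). Compound 4 keeps an aromatic ring at this position, so the large gain over compound 1 is expected to be kept in this assay. No measured compound carries a five-membered ring here, so whether the smaller ring sits at the level of compound 2 and compound 3 or somewhat under it is not shown. For compound 4 the expected step is a number 9.5 percentage points lower from compound 3 to compound 4 (within the scatter), within the scatter. Compound 4 is therefore expected to give about 45% in this assay, between 25% and 65%.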

Compound 4, a percentage reported as inhibition, at one concentration (the size of the read-out at that concentration, not a potency): 10%
Beside the measured number, compound 4's estimate is 35 percentage points above it; the measured number lies below the stated range.
By their numbers in this assay, from the lowest: compounds 4 and 1 (each within the scatter of the next); then compounds 3 and 2 (each within the scatter of the next).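

In this assay, an aromatic ring on this carbon is not enough on its own: thiophen-3-yl in place of 4-formylphenyl gives a number 44.5 percentage points lower from compound 3 to compound 4 (beyond the scatter) and in place of 4-methoxyphenyl gives a number 52.2 percentage points lower from compound 2 to compound 4 (beyond the scatter), so the gain seen with the two substituted six-membered rings does not extend to every aryl group. Against bromo, thiophen-3-yl gives a number 0.2 percentage points lower from compound 1 to compound 4 (within the scatter), which means that at this position the large gain over bromo is confined, among the groups shown, to 4-methoxyphenyl and 4-formylphenyl. No measurement at hand accounts for the loss on moving to thiophen-3-yl.

Still open, as far as these compounds go, is whether the loss goes with the five-membered sulfur-containing ring itself or with the absence of a substituent on the ring, a question that an unsubstituted phenyl and a methoxy-bearing thiophen-3-yl would help to separate. Also open, from the compounds shown here alone, is how other groups at this carbon would read out, such as thiophen-2-yl, furan-3-yl, a pyridine ring or a 4-aminophenyl group.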